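A few compounds are considered here, and "the series" means these few. Any claim that something is new, unique, unknown or untested is made for them only; others in the source may bear on it.

Measured compounds in a functional assay on Ehrlich cells (Mus musculus) for cytotoxicity, read by MTT assay, with a stated time of 24 h; a higher number here means a weaker inhibitor, a lower number a stronger inhibitor:
- compound 1 `C[C@H](Nc1nc2cc(Cl)c(F)cc2s1)c1ccccc1` gives 36600 nM
- compound 2 `CC[C@H](Nc1nc2cc(Cl)c(F)cc2s1)c1ccccc1` gives 32200 nM
- compound 3 `Fc1cc2sc(N[C@@H]3CCCC[C@@H]3OCc3ccccc3)nc2cc1Cl` gives 20600 nM

All three share the same core and differ only in the group on the nitrogen. Compound 1, with a phenyl on a short saturated chain, sits among numbers that all lie within the usual scatter of one another; neither compound 2 nor compound 3 is separated from it by more than that scatter.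

Compound 4 `C[C@H](Nc1nc2cc(Cl)c(F)cc2s1)C1CCCCC1` differs from compound 1 by cyclohexyl in place of phenyl on a saturated chain carbon bound to a nitrogen on an aromatic ring and a saturated chain carbon. Among the compounds with values here, no measured step changes this group, so none bears on it directly; the only step seen, a 1.1-fold lower number from compound 1 to compound 2 (0.06 log units; within the scatter), changed a different part and stayed within the scatter. Nothing here points to a shift in this assay beyond the scatter, and compound 4 is therefore estimated at 32000 nM, in a range from 12000 nM to 85000 nM, an expected step of a 1.1-fold lower number from compound 1 to compound 4 (0.06 log units; within the scatter).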

Compound 4, half-maximal inhibitory concentration: 29800 nM
Estimate against measurement, compound 4: 1.1-fold (0.03 log units) above; measured number inside the range.
By their numbers in this assay, from the lowest: compounds 3, 4, 2 and 1 (each within the scatter of the next).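

Compound 4 is the first compound shown with a change to the ring on this saturated chain carbon, and in this assay the step of cyclohexyl in place of phenyl is a 1.2-fold lower number from compound 1 to compound 4 (0.09 log units; within the scatter) and stays within the scatter. At this position, then, losing the aromatic character of a six-membered carbon ring does not separate the two compounds in this assay. Nothing available explains this result. The compounds shown leave open whether a ring carrying an amine or a carboxylic acid, or a longer chain in place of the ring, would move the number beyond the scatter.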